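Swapping the Halogenated Ring on a Piperidine Oxalamide

A few compounds are considered here, and "the series" means these few. Any claim that something is new, unique, unknown or untested is made for them only; others in the source may bear on it.

Compound 1 `NS(=O)(=O)NCCCNC(=O)/C(=N/O)Nc1ccc(F)c(Cl)c1` gives 10300 nM in an assay on isolated protein for inhibition of Indoleamine 2,3-dioxygenase 1 (Homo sapiens); a higher number here means a weaker inhibitor, a lower number a stronger inhibitor.
Compound 2 `O=C(Nc1ccc(F)c(Cl)c1)C(=O)N1CCC(c2ccccc2)CC1` gives > 60000 nM in this assay.

For compound 2 the value is only a limit of this assay, not a measured number (the limit of > 60000 nM in this assay, at which 1 of the 2 values shown sits). Compound 3 `O=C(Nc1ccc(Cl)cc1)C(=O)N1CCC(c2ccccc2)CC1` has not yet been measured. It differs from compound 2 by 4-chlorophenyl in place of 3-chloro-4-fluorophenyl on an amide-type nitrogen. For the measured compounds named here, no measured step covers this change, so its size cannot be read from the data. The change is expected to amount to a step that the limit leaves unreadable from compound 2 to compound 3, which is no shift beyond the usual scatter. Compound 3 is therefore expected to give about 70000 nM, within a range from 20000 nM to 250000 nM.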

Compound 3, half-maximal inhibitory concentration: > 60000 nM
Compound 3 was reported as a limit (the forecaster's own chance of this, stated with the estimate: 75%); the middle value is on the limit's open side.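

For the compounds shown here, compound 2 and compound 3 both stand at a limit of this assay rather than at a number, so no step between them can be read. From the compounds shown here alone, whether 4-chlorophenyl or 3-chloro-4-fluorophenyl gives the stronger inhibitor stays open.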